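The compounds below may be only part of what the source reports. "The series", "measured", "known", "first", "only" and "open" are said of these compounds alone.

Of the compounds shown here, three have been tested in a functional assay on KETR3 cells (Homo sapiens) for inhibition, read by MTT assay, with a stated time of 120 h; on this read-out higher numbers stand for weaker inhibition and lower numbers for stronger inhibition. Compound 2 `CC(NC(=O)c1ccc(-c2ccc(NC(=O)Nc3cc(C(F)(F)F)ccc3Cl)cc2)cc1)c1ccccc1` gives 16800 nM, the lowest number among the three. Compound 3 `CC(NC(=O)c1ccc(-c2ccc(NC(=O)Nc3ccc(Cl)c(C(F)(F)F)c3)cc2)cc1)c1ccccc1` gives 19300 nM, and a 1.1-fold higher number from compound 2 to compound 3 (0.06 log units; within the scatter), so the two cannot be told apart. Compound 1 `CC1CN(C(=O)c2ccc(-c3ccc(NC(=O)Nc4ccc(Cl)c(C(F)(F)F)c4)cc3)cc2)CC(C)O1` gives 41900 nM.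

Compound 4 `CC1CN(C(=O)c2ccc(-c3ccc(NC(=O)Nc4cc(C(F)(F)F)ccc4Cl)cc3)cc2)CC(C)O1` has not been measured in this assay. It differs from compound 2 in one place: 2,6-dimethylmorpholin-4-yl in place of (1-phenylethyl)amino on a carbonyl carbon.

Going by the values given here, one measured step bears on this change, in the opposite direction: a 2.2-fold lower number from compound 1 to compound 3 (0.34 log units; beyond the scatter). Read backwards, that step suggests replacing the (1-phenylethyl)amino group with the 2,6-dimethylmorpholin-4-yl group raises the number by a modest amount. The other step, between compound 2 and compound 3, shows that the two aryl groups on the amide-type nitrogen give numbers within the scatter, so the same modest rise is expected to carry over to the present pair.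

Compound 4 is therefore expected to come in around 37000 nM, with a range from 18000 nM to 75000 nM. The expected step is a 2.2-fold higher number from compound 2 to compound 4 (0.34 log units; beyond the scatter), a weakening of inhibition.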

Compound 4, half-maximal inhibitory concentration: > 50000 nM
Compound 4: only a limit was reported; the forecaster's own chance of this, stated with the estimate: 10%; middle value at least 1.3-fold (0.13 log units) from the limit.
By their numbers in this assay, from the lowest: compounds 2 and 3 (each within the scatter of the next); then compound 1. At a limit, above all of these: compound 4.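

In this assay, placing 2,6-dimethylmorpholin-4-yl in place of (1-phenylethyl)amino on a carbonyl carbon gives an at least 2.9-fold higher number from compound 2 to compound 4 (0.47 log units; beyond the scatter), so the weakening seen earlier with the 4-chloro-3-(trifluoromethyl)phenyl group also appears with the 2-chloro-5-(trifluoromethyl)phenyl group: the same change on two cores in this assay, a 2.2-fold lower number (0.34 log units; beyond the scatter) from compound 1 to compound 3 and an at least 2.9-fold lower number (0.47 log units; beyond the scatter) from compound 4 to compound 2; the limit leaves it open whether they differ

Compound 4 gives only a limit of > 50000 nM, not a number.

With 2,6-dimethylmorpholin-4-yl on the carbonyl carbon, exchanging the aryl group on the amide-type nitrogen gives an at least 1.1-fold higher number from compound 1 to compound 4 (0.07 log units; that floor lies within the scatter), so no effect of that exchange can be read on this core either: the same change on two cores in this assay, a 1.1-fold higher number (0.06 log units; within the scatter) from compound 2 to compound 3 and an at least 1.1-fold lower number (0.07 log units; that floor lies within the scatter) from compound 4 to compound 1; the limit leaves it open whether they differ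

As far as these compounds go, the true value of compound 4 remains open, and so does which part of the change counts, the amide hydrogen or the aromatic ring of (1-phenylethyl)amino. An N-methyl-N-(1-phenylethyl)amino group, which keeps the ring but lacks that hydrogen, could help separate the two.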